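Carboxy in place of trifluoromethyl at the chain end

A few compounds are considered here, and "the series" means these few. Any claim that something is new, unique, unknown or untested is made for them only; others in the source may bear on it.

Within the data shown here, the three compounds measured so far share one core and differ in the chain carried on an aromatic nitrogen. In an ADME assay on HeLa cells (Homo sapiens) for cytotoxicity, read by ATP content, with a stated time of 3 days (on this read-out higher numbers stand for lower toxicity in this test and lower numbers for higher toxicity in this test), compound 1 `CS(=O)(=O)c1ccc(-n2c(=O)n(Cc3cc4cc(Cl)ccc4n3CCCC#N)c3cnccc32)cc1` gives only a limit of the test, > 50000 nM. Compound 2 `CS(=O)(=O)CCCn1c(Cn2c(=O)n(C3CC3)c3ccncc32)cc2cc(Cl)ccc21` likewise reaches only the limit, > 50000 nM in this assay. Compound 3 `O=c1n(Cc2cc3cc(Cl)ccc3n2CCCC(F)(F)F)c2cnccc2n1C1CC1` stands at the same limit, > 50000 nM in this assay. Among the measured compounds shown here, the one step between neighbours, a step that the two limits leave unreadable from compound 2 to compound 3, cannot be read because of the limit of > 50000 nM in this assay, at which 3 of the 3 values shown sit. So compound 3 stands where every measured compound stands: at the limit, with no number behind it.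

Compound 4 `O=C(O)CCCn1c(Cn2c(=O)n(C3CC3)c3ccncc32)cc2cc(Cl)ccc21` differs from compound 3 by carboxy in place of trifluoromethyl on a saturated chain carbon, three bonds along the chain from an aromatic nitrogen. For the measured compounds named here, the single measured step bears on it only in kind: it exchanged a group at the same place on the chain and left the read-out at the limit. The carboxy group itself has no precedent among these compounds, so no step beyond the scatter is expected in this assay in either direction. Compound 4 is therefore expected to return the limit once more, and the expected step that the limit leaves unreadable from compound 3 to compound 4 is essentially none. The estimate for compound 4 in this assay is 60000 nM, with a range from 20000 nM to 200000 nM, most likely reported only as a limit.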

Compound 4, half-maximal cytotoxic concentration: > 50000 nM
Compound 4 gave a limit, no number; the forecaster's own chance of this, stated with the estimate: 85%; the middle value lies beyond the limit too.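

Compound 4, like compound 2 and compound 3, gives only a limit in this assay, so the steps from compound 3 and from compound 2 to compound 4 cannot be read: the limit of > 50000 nM in this assay, at which 4 of the 4 values shown sit.

The compounds shown leave open whether these chain ends differ at all in this assay, and at what concentration any of them would lower the read-out.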